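Removing the Trifluoromethyl Group: What to Expect for Compound 4

The source may report more compounds than this note shows. Statements on the series, on what has been measured and on what is new or still open speak of the compounds shown alone.

In an ADME assay on NIH3T3 cells (Mus musculus) for cytotoxicity, read by XTT assay, with a stated time of 24 h (on this read-out lower numbers stand for stronger inhibition and higher numbers for weaker inhibition), compound 1 `Fc1ccc(C2CC(c3ccc(Cl)s3)=NN2c2nc(-c3ccc(C(F)(F)F)cc3)cs2)cc1` gives > 500 ug/mL, which is a limit of the assay rather than a number. Compound 3 `Cc1ccc(C2=NN(c3nc(-c4ccc(C(F)(F)F)cc4)cs3)C(c3ccc(F)cc3)C2)s1` likewise gives > 500 ug/mL, again a limit. Compound 2 `Cc1ccc(C2=NN(c3nc(-c4ccc(S(C)(=O)=O)cc4)cs3)C(c3ccc(F)cc3)C2)s1` gives a measurable 374 ug/mL. Compound 1 therefore stands at the limit of > 500 ug/mL in this assay, at which 2 of the 3 values shown sit, with no number of its own. The step that the two limits leave unreadable from compound 1 to compound 3 cannot be read because both of its ends are limits. For the measured compounds named here, the only measured step that touches the trifluoromethyl group, an at least 1.3-fold higher number from compound 2 to compound 3 (0.12 log units; that floor lies within the scatter), is a floor lying within the scatter. Compound 4 `Fc1ccc(C2CC(c3ccc(Cl)s3)=NN2c2nc(-c3ccccc3)cs2)cc1` differs from compound 1 by hydrogen in place of trifluoromethyl on an aromatic carbon. Going by the values given here, no measured step tests this removal directly, so no change beyond the scatter is expected. Compound 4 is therefore estimated at 500 ug/mL, between 200 ug/mL and 1000 ug/mL, an expected step of a number no higher from compound 1 to compound 4 (the limit leaves the size open).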

Compound 4, half-maximal inhibitory concentration: > 500 ug/mL
Compound 4 gave a limit, no number; the forecaster's own chance of this, stated with the estimate: 60%; the middle value lies on the limit itself.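

For the compounds shown here, compound 1 and compound 4 both end at a limit rather than a number, so no step between them can be read: the limit of > 500 ug/mL in this assay, at which 3 of the 4 values shown sit.
The compounds shown leave open whether hydrogen in place of trifluoromethyl shifts the true value at all.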